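The compounds below may be only part of what the source reports. "The series", "measured", "known", "first", "only" and "open" are said of these compounds alone.

Working notes on the series. Three compounds have numbers in a functional assay on CHO cells for antagonist activity at sphingosine 1-phosphate receptor 2 (Homo sapiens), read by calcium flux; a lower number here means a stronger inhibitor, a higher number a weaker inhibitor. Compound 1 `CCOc1cc2[nH]c(Cc3nn(CC(=O)N4CCOCC4)c(=O)c4ccccc34)nc2cc1Cl` gives 10 nM, compound 3 `O=C(O)Cn1nc(Cc2nc3cc(Cl)c(OCC(F)F)cc3[nH]2)c2ccccc2c1=O` gives 12 nM, and compound 2 `CCn1nc(CC(=O)Nc2ccc(OC(F)(F)F)c(Cl)c2)c2ccccc2c1=O` gives 199 nM, the highest of the three, beyond the scatter from both of the others. Compound 4 `O=C(O)Cn1nc(CC(=O)Nc2ccc(OC(F)(F)F)c(Cl)c2)c2ccccc2c1=O` is not yet measured; it differs from compound 2 in one place, (carboxy in place of methyl on a saturated chain carbon bound to an aromatic nitrogen), which read one bond further out is ethyl to carboxymethyl. Among the compounds with values here, no measured pair shows this change on its own, and compound 3 carries a carboxymethyl on a different core, so its value and that of compound 2 can only be set side by side. A small move toward a lower number is expected for compound 4, a 2.0-fold lower number from compound 2 to compound 4 (0.30 log units; within the scatter), possibly within the scatter. In this assay compound 4 is estimated at 100 nM, between 30 nM and 350 nM.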

Compound 4, half-maximal inhibitory concentration: 389 nM
Estimate against measurement, compound 4: 3.9-fold (0.59 log units) below, outside the stated range (above it).
By their numbers in this assay, from the lowest: compounds 1 and 3 (each within the scatter of the next); then compounds 2 and 4 (each within the scatter of the next).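

In this assay, within the data shown here, the step gives the first direct reading of this change: ethyl to carboxymethyl gives a 2.0-fold higher number from compound 2 to compound 4 (0.29 log units; within the scatter). At this saturated chain carbon bound to an aromatic nitrogen, the added carboxy therefore gives no shift that can be separated from the scatter on this core. The reading holds for this one pair only.

Going by these compounds, whether an amine, a methyl ester or a longer chain at this place would move the number beyond the scatter remains open. No measurement here bears on why this change behaves as it does.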